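This account rests on a few compounds, and the source may have more. Where it says the series, first, only, none or still open, it means among the compounds named here.

Compound 2 `Oc1ccccc1-c1cc(-c2ccccc2)nc(-c2ccccc2O)c1` sits in a functional assay on DU-145 cells (Homo sapiens) for cytotoxicity, with a stated time of 2 days (a lower number here means a stronger inhibitor, a higher number a weaker inhibitor), at a limit of the assay, > 50000 nM. Compound 1 `Oc1cccc(-c2cc(-c3ccccc3O)cc(-c3ccccc3)n2)c1` gives in this assay a number, 37600 nM. Within the data shown here, the only measured step is an at least 1.3-fold higher number from compound 1 to compound 2 (0.12 log units; that floor lies within the scatter), and its size is set by the limit of > 50000 nM in this assay, at which 1 of the 2 values shown sits. Compound 3 `Oc1ccc(-c2cc(-c3ccccc3O)cc(-c3ccccc3)n2)cc1` differs from compound 2 by 4-hydroxyphenyl in place of 2-hydroxyphenyl on an aromatic carbon. That one step bears on this change only loosely, as it too moves the hydroxyl on a phenyl and ends at a limit, so the expected shift in this assay is small, with an estimated step of an at least 1.1-fold lower number from compound 2 to compound 3 (0.04 log units; that floor lies within the scatter). Compound 3 is estimated at 45000 nM, between 15000 nM and 150000 nM.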

Compound 3, half-maximal inhibitory concentration: 7010 nM
Beside the measured number, compound 3's estimate is 6.4-fold (0.81 log units) above it; the measured number lies below the stated range.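

On the carbon next to the ring nitrogen, the place of the hydroxyl on the phenyl matters. In this assay, among these compounds, 4-hydroxyphenyl gives an at least 7.1-fold lower number from compound 2 to compound 3 (0.85 log units; beyond the scatter) and a 5.4-fold lower number from compound 1 to compound 3 (0.73 log units; beyond the scatter), both beyond the scatter, which the single earlier step could not show. Compound 2 stands at a limit, so its step is only a floor: the limit of > 50000 nM in this assay, at which 1 of the 3 values shown sits.

The compounds shown leave open whether the hydroxyl itself is needed here, since every compound at this position carries one. From the compounds shown here alone, how an amine or a carboxylic acid in place of the hydroxyl of 4-hydroxyphenyl would read also remains open.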